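Moving a Methylsulfanyl Group Around a Urea Phenyl Ring

The compounds below may be only part of what the source reports. "The series", "measured", "known", "first", "only" and "open" are said of these compounds alone.

Compound 1 `CSc1ccccc1NC(=O)N[C@H]1CC[C@H](Oc2ccc(F)cc2)CC1` reaches only a limit in a functional assay on CRL2813 cells (Homo sapiens) for cytotoxicity, read by sulforhodamine B assay, with a stated time of 5 days; a higher number here means a weaker inhibitor, a lower number a stronger inhibitor: > 20000 nM.
Compound 2 `O=C(Nc1ccc([N+](=O)[O-])cc1)N[C@H]1CC[C@H](Oc2ccc(F)cc2)CC1` gives 2300 nM in this assay.
Compound 3 `O=C(Nc1cccc(Cl)c1)N[C@H]1CC[C@H](Oc2ccc(F)cc2)CC1` gives 5900 nM in this assay.

Compound 3 has the highest of the two numbers; its nearest neighbour is compound 2, with a 2.6-fold higher number from compound 2 to compound 3 (0.41 log units; beyond the scatter). Compound 4 `CSc1cccc(NC(=O)N[C@H]2CC[C@H](Oc3ccc(F)cc3)CC2)c1` differs from compound 3 by methylsulfanyl in place of chloro on an aromatic carbon. For the measured compounds named here, no measured step exchanges chloro for methylsulfanyl at the same position. The closest is an at least 3.3-fold lower number from compound 1 to compound 3 (0.53 log units; beyond the scatter), which changed both the group and its place, and compound 1 sits at a limit there (the limit of > 20000 nM in this assay, at which 1 of the 3 values shown sits). This gives no clean guide, so no step beyond the scatter is expected. Compound 4 is estimated at 8000 nM, with a range from 3000 nM to 25000 nM, meaning an expected 1.4-fold higher number from compound 3 to compound 4 (0.13 log units; within the scatter).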

Compound 4, half-maximal inhibitory concentration: 11100 nM
Beside the measured number, compound 4's estimate is 1.4-fold (0.14 log units) below it; low and high end bracket the measured number.
By their numbers in this assay, from the lowest: compound 2; then compounds 3 and 4 (each within the scatter of the next). At a limit, above all of these: compound 1.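

In this assay, methylsulfanyl in place of chloro at this ring position gives a 1.9-fold higher number from compound 3 to compound 4 (0.27 log units; within the scatter), so the two groups cannot be told apart here. The 4-nitrophenyl compound also stands clearly apart from the 3-(methylsulfanyl)phenyl compound, with a 4.8-fold higher number from compound 2 to compound 4 (0.68 log units; beyond the scatter). Compound 1 gives only a limit, > 20000 nM, and an at least 1.8-fold lower number from compound 1 to compound 4 (0.25 log units; that floor lies within the scatter) therefore cannot settle whether moving methylsulfanyl on the ring matters. Open, going by these compounds, is how an amine or a carboxylic acid at this ring position would read in this assay.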